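Ecdysone receptor agonists: swapping an iodine-bearing ring

The source may report more compounds than this note shows. Statements on the series, on what has been measured and on what is new or still open speak of the compounds shown alone.

Three close relatives of one diacylhydrazine share a core and differ only in the halogen on one of the two aromatic rings. In an assay on cells for agonist activity at ecdysone receptor (Bombyx mori), read by a luciferase reporter, with a stated time of 24 h (a lower number here means that less compound is needed, a higher number that more compound is needed for the effect), compound 1 `CC(C)(C)N(NC(=O)c1ccccc1Cl)C(=O)c1ccccc1Cl` gives 331 nM, compound 2 `CC(C)(C)N(NC(=O)c1ccccc1Br)C(=O)c1ccccc1Cl` gives 316 nM, and compound 3 `CC(C)(C)N(NC(=O)c1ccccc1I)C(=O)c1ccccc1Cl` gives 1290 nM. Compound 3 therefore carries the highest number of the three: the steps of a 3.9-fold higher number from compound 1 to compound 3 (0.59 log units; beyond the scatter) and a 4.1-fold higher number from compound 2 to compound 3 (0.61 log units; beyond the scatter) both lie beyond the scatter, while a 1.0-fold lower number from compound 1 to compound 2 (0.02 log units; within the scatter) does not.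

Compound 4 `CC(C)(C)N(NC(=O)c1cccc(Cl)c1)C(=O)c1ccccc1Cl` changes the same ring again: 3-chlorophenyl in place of 2-iodophenyl on a carbonyl carbon. Within the data shown here, no measured step covers this exact swap, because the halogen both changes from iodine to chlorine and moves into the 3-chlorophenyl group. Among the measured compounds shown here, the closest guidance is that compound 1, with chloro where compound 3 has iodo, gave the lower number in this assay, so removing iodine is expected to bring the number down, though the new chlorine sits in a group none of the measured compounds contains.

Compound 4 is therefore expected to give roughly 600 nM, within 200 nM to 2500 nM. That estimate corresponds to an expected step of a 2.2-fold lower number from compound 3 to compound 4 (0.33 log units; beyond the scatter).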

Compound 4, half-maximal effective concentration: 155 nM
For compound 4 the middle estimate is 3.9-fold (0.59 log units) above the measured one, and the stated range ends above it.
By their numbers in this assay, from the lowest: compound 4; then compounds 2 and 1 (each within the scatter of the next); then compound 3.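

In this assay, the change to 3-chlorophenyl does more than undo the high number of the iodine compound, an 8.3-fold lower number from compound 3 to compound 4 (0.92 log units; beyond the scatter): it also goes past the two compounds that carry a chloro or bromo group, with a 2.0-fold lower number from compound 2 to compound 4 (0.31 log units; beyond the scatter) and a 2.1-fold lower number from compound 1 to compound 4 (0.33 log units; beyond the scatter). Among these compounds, compound 1 and compound 4 differ only in having 2-chlorophenyl or 3-chlorophenyl on the carbonyl carbon, so with the halogen held the same, its place on the ring alone shifts the number beyond the scatter, which swapping one halogen for another among the earlier compounds could not show. No measurement available here explains this shift.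

As far as these compounds go, it remains open whether a 3-bromophenyl or 3-iodophenyl group would follow the order of halogens seen among compound 1, compound 2 and compound 3, and what a 3-methylphenyl or 3-methoxyphenyl group would do with no halogen there at all. A single compound also cannot show whether the 3-chlorophenyl group keeps its lower number when the 2-chlorophenyl group on the other carbonyl is replaced.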